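A few compounds are considered here, and "the series" means these few. Any claim that something is new, unique, unknown or untested is made for them only; others in the source may bear on it.

Compound 1 `C=Cc1cc2cc([C@]3(OC)C[C@@H](C(=O)N[C@]4(C(=O)NS(=O)(=O)C5CC5)C[C@H]4C=C)N(C(=O)[C@@H](NC(=O)OC(C)(C)C)C(C)(C)C)C3)ccc2cc1OC`: 0.6 h
Compound 2 `C=C[C@@H]1C[C@]1(NC(=O)[C@@H]1C[C@]2(OC)CN1C(=O)[C@H](C(C)(C)C)NC(=O)OCCCCCCc1cc3cc2ccc3cc1OC)C(=O)NS(=O)(=O)C1CC1`: 0.417 h

In an ADME assay on microsomes from liver (Homo sapiens) for metabolic stability, using NADPH (a higher number here means that the compound lasts longer, a lower number that the compound disappears faster), compound 2 and compound 1 give values that lie within the scatter of each other, so compound 2 does not stand apart from compound 1. Compound 3 `COc1cc2ccc3cc2cc1CCCCCCOC(=O)N[C@@H](C(C)(C)C)C(=O)N1C[C@@]3(OC)C[C@H]1C(=O)N[C@]1(C(=O)NS(=O)(=O)C2CC2)C[C@H]1C1CC1` differs from compound 2 by cyclopropyl in place of vinyl on a saturated ring carbon. Among the compounds with values here, no step between measured compounds speaks to this change, so any expectation rests on compound 2 alone. The step from a 1.4-fold higher number from compound 2 to compound 3 (0.16 log units; within the scatter) is expected to stay within the scatter. Compound 3 is estimated at 0.6 h, in the range 0.3 h to 1.2 h.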

Compound 3, half-life: 1.65 h
Estimate against measurement, compound 3: 2.8-fold (0.44 log units) below, outside the stated range (above it).
By their numbers in this assay, from the lowest: compounds 2 and 1 (each within the scatter of the next); then compound 3.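

In this assay, cyclopropyl in place of vinyl on a saturated ring carbon of a three-membered non-aromatic ring of carbon only gives a 4.0-fold higher number from compound 2 to compound 3 (0.60 log units; beyond the scatter) and so lies beyond the scatter. Within the data shown here, this shows that the number responds to the group at this place, which the earlier compounds could not show. Nothing available here accounts for the size of this step. On these data alone, whether an ethyl group or a cyclobutyl group at the same place would give a number closer to compound 2 or to compound 3 stays open.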